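Benzyl substituent change on compound 3

The source may hold more compounds than are shown below. What is called first, only, known or untested is meant among the compounds shown, and "the series" means these compounds.

In an assay on isolated protein for inhibition of Amine oxidase [flavin-containing] A (Homo sapiens), read by fluorescence, with stated times of 15 min and 20 min (on this read-out lower numbers stand for stronger inhibition and higher numbers for weaker inhibition), compound 1 `CC(C)(C)c1cc(/C=C/C(=O)NC2CCN(Cc3ccccc3)CC2)cc(C(C)(C)C)c1O` gives 42500 nM, compound 2 `CC(C)(C)c1cc(/C=C/C(=O)NCCC2CCN(Cc3ccccc3)CC2)cc(C(C)(C)C)c1O` gives 62300 nM and compound 3 `COc1ccc(CN2CCC(CCNC(=O)/C=C/c3cc(C(C)(C)C)c(O)c(C(C)(C)C)c3)CC2)cc1` gives 72500 nM. Compound 3 has the highest of the three numbers; compound 2 is nearest and compound 1 furthest, both within the scatter. For the measured compounds named here, the single one-place step is a 1.2-fold higher number from compound 2 to compound 3 (0.07 log units; within the scatter), methoxy in place of hydrogen on an aromatic carbon. Compound 4 `Cc1ccccc1CN1CCC(CCNC(=O)/C=C/c2cc(C(C)(C)C)c(O)c(C(C)(C)C)c2)CC1` differs from compound 3 by 2-methylphenyl in place of 4-methoxyphenyl on a saturated chain carbon bound to an amine nitrogen in a ring. Going by the values given here, the step from compound 2 to compound 3 bears on the loss of the methoxy and was within the scatter; no measured step covers the entering 2-methylphenyl. A step within the scatter is therefore expected, with no firm direction. For compound 4 the estimate is 60000 nM with a range of 25000 nM to 140000 nM, meaning an expected step of a 1.2-fold lower number from compound 3 to compound 4 (0.08 log units; within the scatter).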

Compound 4, half-maximal inhibitory concentration: 69300 nM
For compound 4 the middle estimate is 1.2-fold (0.06 log units) below the measured one, within the range that was stated.
By their numbers in this assay, from the lowest: compounds 1, 2, 4 and 3 (each within the scatter of the next).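

In this assay, 2-methylbenzyl in place of 4-methoxybenzyl on the amine nitrogen in a ring gives a 1.0-fold lower number from compound 3 to compound 4 (0.02 log units; within the scatter). Methyl in place of hydrogen on an aromatic carbon gives a 1.1-fold higher number from compound 2 to compound 4 (0.05 log units; within the scatter), so a second kind of aromatic substituent, after methoxy, also stays within the scatter of the plain benzyl of compound 2. No supporting data bear on why these numbers stay so close.

Still open, from the compounds shown here alone, is whether an amine or a carboxylic acid on this aromatic ring would shift the number beyond the scatter. Also open, going by these compounds, is what a longer chain in place of the benzyl would do.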